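Ethynyl in place of furan-3-yl: notes on compound 4

This account rests on a few compounds, and the source may have more. Where it says the series, first, only, none or still open, it means among the compounds named here.

Measured so far in a functional assay on CEM-DNR-bulk cells (Homo sapiens), read by MTT assay, with a stated time of 72 h (a lower number here means a stronger inhibitor, a higher number a weaker inhibitor), for three compounds:
- compound 1 `C#Cc1cn([C@@H]2O[C@H](CO)[C@@H](O)[C@H]2O)c2ncnc(OC)c12` gives 3490 nM as a number
- compound 2 `O=c1[nH]cnc2c1c(-c1ccccc1)cn2[C@@H]1O[C@H](CO)[C@@H](O)[C@H]1O` gives > 20000 nM as a limit of the assay
- compound 3 `Cc1nc(N)c2c(-c3ccoc3)cn([C@@H]3O[C@H](CO)[C@@H](O)[C@H]3O)c2n1` gives > 20000 nM as a limit of the assay

Going by these compounds, compound 3 has no number in this assay but only the limit > 20000 nM and its true value stays open. The series shows the limit of > 20000 nM in this assay, at which 2 of the 3 values shown sit, and compound 3 is one of those two.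

Compound 4 `C#Cc1cn([C@@H]2O[C@H](CO)[C@@H](O)[C@H]2O)c2nc(C)nc(N)c12` differs from compound 3 by ethynyl in place of furan-3-yl on an aromatic carbon and so ethynyl stands in place of furan-3-yl on an aromatic carbon.

Among the compounds with values here, no step between measured compounds is available. Within the data shown here, the only measured compound with ethynyl is compound 1 (3490 nM) and its core differs from that of compound 4, so this expectation rests on one compound. A step beyond the scatter is expected in this assay toward a stronger inhibitor, with its size uncertain since it starts from a limit. The estimated change is an at least 8.0-fold lower number from compound 3 to compound 4 (0.90 log units; beyond the scatter) in this series. Compound 4 is estimated at 2500 nM with an expected range of 250 nM to 20000 nM and a real chance of a limit instead of a number.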

Compound 4, half-maximal inhibitory concentration: 12600 nM
Beside the measured number, compound 4's estimate is 5.0-fold (0.70 log units) below it, and the stated range covers the measured number.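

With ethynyl on this aromatic carbon, two ring bonds from the ring nitrogen, the core shared by compound 3 and compound 4 now gives a measured number in this assay, where the furan-3-yl compound gave only a limit. The change reads as an at least 1.5-fold lower number from compound 3 to compound 4 (0.20 log units; that floor lies within the scatter), so this pair fixes only a floor for the step, and that floor does not by itself show a real gain in potency from the swap. Compound 3 holds a limit and not a number, and that limit recurs in the series: the limit of > 20000 nM in this assay, at which 2 of the 4 values shown sit.

Going by these compounds, the true value of compound 3 stays open, and with it the real size of the step and whether that step clears the scatter. Within the data shown here, also open is how a nitrile, a longer alkynyl chain such as propynyl, or a primary amine would read on this same aromatic carbon of the shared core, so no trend at this position can yet be drawn from the single pair.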